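Methyl for cyclopropyl on the ring nitrogen of compound 3

A few compounds are considered here, and "the series" means these few. Any claim that something is new, unique, unknown or untested is made for them only; others in the source may bear on it.

Compound 3 `c1ccc(Cn2nnc3c(NC4CC4)nc(-c4ccccc4)nc32)cc1` shows the lowest number of the three measured in an assay on isolated protein for binding affinity to adenosine receptor A1 (Bos taurus) (on this read-out lower numbers stand for stronger inhibition and higher numbers for weaker inhibition), at 11000000 nM. Compound 1 `OCCCNc1nc(-c2ccccc2)nc2c1nnn2Cc1ccccc1` gives 21400000 nM, and the step of a 1.9-fold lower number from compound 1 to compound 3 (0.29 log units; within the scatter) stays within the scatter. Compound 2 `CNc1nc(-c2ccccc2)nc2c1nnn2Cc1ccccc1Cl` gives 191000000 nM, a number well above compound 3.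

The next change is methyl in place of cyclopropyl on a nitrogen on an aromatic ring, giving compound 4 `CNc1nc(-c2ccccc2)nc2c1nnn2Cc1ccccc1`. Going by the values given here, no measured step covers methyl against cyclopropyl alone: compound 2 carries methylamino but also a chlorine on the benzyl ring, so its two values only hint that the methyl variant may sit higher. Among the compounds with values here, with one within-scatter step as the sole direct precedent, a small rise is expected, a 2.7-fold higher number from compound 3 to compound 4 (0.44 log units; beyond the scatter), and compound 4 is estimated at 30000000 nM, between 8000000 nM and 120000000 nM.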

Compound 4, inhibition constant: 353000000 nM
For compound 4 the middle estimate is 12-fold (1.07 log units) below the measured one, and the stated range ends below it.
By their numbers in this assay, from the lowest: compounds 3 and 1 (each within the scatter of the next); then compounds 2 and 4 (each within the scatter of the next).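

In this assay, the nitrogen on the aromatic ring proves sensitive to its substituent: cyclopropylamino to methylamino is a large step (a 32-fold higher number from compound 3 to compound 4 (1.51 log units; beyond the scatter)), and 3-hydroxypropyl to methyl is large too (a 16-fold higher number from compound 1 to compound 4 (1.22 log units; beyond the scatter)). Hydrogen in place of chloro on an aromatic carbon leaves the two methylamino compounds within the scatter (a 1.8-fold higher number from compound 2 to compound 4 (0.27 log units; within the scatter)), so here the methyl group, not the chloro, marks the large steps. No evidence on the cause of these steps is at hand.

Still open, as far as these compounds go, is how ethyl, isopropyl or cyclobutyl on this nitrogen would read, and whether the cyclopropyl step holds with chloro on the aromatic carbon.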